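The source may report more compounds than this note shows. Statements on the series, on what has been measured and on what is new or still open speak of the compounds shown alone.

Measured compounds and values in an assay on isolated protein for inhibition of serine/threonine-protein kinase 10 (Homo sapiens), read by thermal shift assay, tested at 10 uM; on this read-out higher numbers stand for stronger stabilisation of the target against heat and lower numbers for weaker stabilisation of the target:
compound 1 `CC(C)(C)c1cc(NC(=O)Nc2cc(C(F)(F)F)cc(C(F)(F)F)c2)n(-c2ccccc2)n1`, -0.5 degrees C
compound 2 `CC(C)(C)c1cc(NC(=O)Nc2ccccc2)n(-c2ccccc2)n1`, 7.2 degrees C
compound 3 `Cc1ccc(-n2nc(C(C)(C)C)cc2NC(=O)Nc2cc(C(F)(F)F)cc(C(F)(F)F)c2)cc1`, -0.5 degrees C

Compound 3 stands level with compound 1 at the digits shown, the two together being the lowest of the three numbers; the nearest to it is compound 1, the furthest compound 2, whose value lies higher by a margin beyond the scatter. Compound 1 and compound 3 share the bis(trifluoromethyl)phenyl urea part, while compound 2 carries a plain phenyl urea.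

The next compound, compound 4 `Cn1nc(C(C)(C)C)cc1NC(=O)Nc1cc(C(F)(F)F)cc(C(F)(F)F)c1`, differs from compound 3 in one place: methyl in place of 4-methylphenyl on an aromatic nitrogen. Among the compounds with values here, the only measured step that touches the group on the aromatic nitrogen is no change at the digits printed from compound 1 to compound 3 (within the scatter), which left the read-out unchanged. Within the data shown here, no other step bears on this position, and no measured compound carries a methyl there. On that basis no step beyond the scatter is expected in this assay for compound 4, the expected step being a number 0.20 degrees C higher from compound 3 to compound 4 (within the scatter). The estimate for compound 4 is therefore -0.3 degrees C, in a range from -2 degrees C to 2.5 degrees C.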

Compound 4, shift of the target's melting temperature: 1.1 degrees C
Compound 4: the middle estimate sits 1.4 degrees C below what was measured; the range from low to high includes it.
By their numbers in this assay, from the lowest: compounds 1 and 3 (each within the scatter of the next); then compound 4; then compound 2.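

In this assay the group on the aromatic nitrogen is not silent after all: with methyl in place of the aromatic ring, the series shows a number 1.6 degrees C higher from compound 3 to compound 4 (beyond the scatter) and also a number 1.6 degrees C higher from compound 1 to compound 4 (beyond the scatter). The earlier change on this ring, no change at the digits printed from compound 1 to compound 3 (within the scatter), touched only an aromatic carbon, so the read-out responds to replacing the whole ring with methyl but not to adding methyl to that ring. No measurement given here explains this modest rise.

Open, from the compounds shown here alone, is whether a hydrogen, an ethyl chain or a cyclohexyl ring on the aromatic nitrogen would follow the methyl or the aromatic rings. Also open, going by these compounds, is whether methyl in this place would produce a similar step with the plain phenyl urea of compound 2.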